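The compounds below may be only part of what the source reports. "The series", "measured", "known", "first", "only" and "open" are said of these compounds alone.

Two diaryl ureas built on a shared core were tested in a functional assay on CNE-2 cells (Homo sapiens) for cytotoxicity, read by MTT assay, with a stated time of 3 days; on this read-out higher numbers stand for weaker inhibition and lower numbers for stronger inhibition. Compound 1 `Cc1cccc(NC(=O)Nc2ccc(Sc3nc(C)cc(C)n3)cc2)c1` gives > 50000 nM, which is a limit of the assay rather than a number. For the measured compounds named here, compound 2 `Cc1cc(C)nc(Sc2ccc(NC(=O)Nc3ccc(OC(F)(F)F)cc3)cc2)n1` gives 22800 nM in this assay, and this is the only numerical value recorded among the two compounds. The remaining result is a limit (the limit of > 50000 nM in this assay, at which 1 of the 2 values shown sits). Compound 3 `Cc1cc(C)nc(Sc2ccc(NC(=O)Nc3ccc(Cl)cc3)cc2)n1` has not yet been measured. It differs from compound 2 by chloro in place of trifluoromethoxy on an aromatic carbon. No measured step of this kind is available among the compounds shown, so the expectation rests on the change itself: the expected step is a 1.3-fold higher number from compound 2 to compound 3 (0.12 log units; within the scatter), most likely one that stays within the usual scatter, or tilts slightly toward weaker inhibition. Compound 3 is therefore estimated to give 30000 nM in this assay, with a plausible range from 10000 nM to 80000 nM.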

Compound 3, half-maximal inhibitory concentration: 13500 nM
Compound 3: the middle estimate sits 2.2-fold (0.35 log units) above what was measured; measured number inside the range.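

In this assay, the change at this ring position gives a 1.7-fold lower number from compound 2 to compound 3 (0.23 log units; within the scatter), so chloro and trifluoromethoxy cannot be told apart here. Compound 3 also provides a comparison across the urea, where 4-chlorophenyl in place of 3-methylphenyl gives an at least 3.7-fold lower number from compound 1 to compound 3 (0.56 log units; beyond the scatter), a difference that goes beyond the scatter. The size of that step is only a minimum, as the value of compound 1 is a limit of the assay and not a number: the limit of > 50000 nM in this assay, at which 1 of the 3 values shown sits.

The compounds shown leave open whether that difference follows from the change of group or from its place on the ring, as both change together in this step. They also do not tell how an amine or a carboxylic acid in place of the chloro would read.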